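The compounds below may be only part of what the source reports. "The series", "measured", "known", "first", "only" and "open" are said of these compounds alone.

Measured compounds:

Compound 1 `COc1ccc(-c2cc(/C=C/C(=O)c3ccc(N)cc3)[nH]n2)cc1`: 99%
Compound 2 `COc1ccc(C(=O)/C=C/c2cc(-c3cc(OC)c(OC)c(OC)c3)n[nH]2)cc1OC`: 95%
Compound 3 `COc1ccc(-c2cc(/C=C/C(=O)c3ccc(N)cc3)[nH]n2)cc1OC`: 104%

The three measured compounds were examined in a functional assay on NCI/ADR-RES cells (Homo sapiens) for cytotoxicity, read by sulforhodamine B assay, with a stated time of 48 h, tested at 0.1 uM; on this read-out higher numbers stand for a weaker effect at the one concentration tested and lower numbers for a stronger effect. Compound 1 gives 99%, compound 3 gives 104% and compound 2 gives 95% in this assay. Compound 3 differs from compound 1 by methoxy in place of hydrogen on an aromatic carbon, and the step of a number 5 percentage points higher from compound 1 to compound 3 (within the scatter) lies within the scatter of this kind of measurement, so the two values cannot be told apart. Compound 2 differs from compound 1 in more than one place, and the difference between the two cores is not broken down here; its value in this assay sits within the scatter of both compound 1 and compound 3, so nothing separates the three.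

Compound 4 `COc1cc(C(=O)/C=C/c2cc(-c3cc(OC)c(OC)c(OC)c3)n[nH]2)cc(OC)c1OC` has not yet been measured. It differs from compound 2 by methoxy in place of hydrogen on an aromatic carbon. For the measured compounds named here, this is the same kind of change as the one from compound 1 to compound 3, though the place is not identical: in compound 4 the entering group is also meta to a methoxy group, which the earlier place does not state. The step from compound 2 to compound 4 is expected to be a number 3 percentage points higher from compound 2 to compound 4 (within the scatter), that is, small, because a number 5 percentage points higher from compound 1 to compound 3 (within the scatter) shows the same kind of change leaving the read-out within the scatter. Compound 4 is therefore estimated to give about 98% in this assay, most likely between 86% and 108%.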

Compound 4, a percentage reported as activity, at one concentration (the size of the read-out at that concentration, not a potency): 106%
Compound 4: the middle estimate sits 8 percentage points below what was measured; the range from low to high includes it.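

Within this assay, methoxy in place of hydrogen on an aromatic carbon gives a number 11 percentage points higher from compound 2 to compound 4 (beyond the scatter), a modest step on the core of compound 2, and set beside the same change on the core of compound 1 the two steps cannot be told apart: the same change on two cores in this assay, a number 5 percentage points higher (within the scatter) from compound 1 to compound 3 and a number 11 percentage points higher (beyond the scatter) from compound 2 to compound 4, 6 percentage points apart, within the scatter of two such steps. Read together, the two pairs give no sign that the core alters the size of this change, so nothing here speaks against carrying it from one core to the other. For the compounds shown here, they do not prove that it transfers, however: the series offers only two pairs, only one of the two steps lies beyond the scatter, and the place is not identical, as the methoxy group entering compound 4 is ortho to one methoxy group and meta to another.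

The compounds shown leave open whether a group other than methoxy, such as a hydroxy group, an ethoxy group or a carboxylic acid, would give a comparable step at this kind of place on either core. They also leave open how the two steps would compare at any concentration other than the single one tested, as one concentration gives the size of the read-out and not a potency.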